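Methoxy removal in an ester series: cytotoxicity expectation

This account rests on a few compounds, and the source may have more. Where it says the series, first, only, none or still open, it means among the compounds named here.

Compound 1 `Cc1nc(C)c(C(=O)Oc2ccccc2/C=C/C(=O)O)nc1C`: 61.8%
Compound 2 `CCOC(=O)/C=C/c1cc(OC)ccc1OC(=O)c1nc(C)c(C)nc1C`: 23.4%

In a functional assay on EA.hy 926 cells (Homo sapiens) for cytotoxicity, read by MTT assay, with stated times of 24 h and 12 h, tested at 25 uM (a lower number here means a weaker effect, a higher number a stronger effect of the compound at the concentration tested), compound 1 gives 61.8%, while compound 2 gives 23.4%. Compound 2 thus stands lowest of the two numbers, with compound 1 higher by a gap beyond the scatter. Going by the values given here, no pair of measured compounds differs in one place only, so no single change is directly anchored. Compound 3 `CCOC(=O)/C=C/c1ccccc1OC(=O)c1nc(C)c(C)nc1C` differs from compound 2 by hydrogen in place of methoxy on an aromatic carbon. The step of a number 6.6 percentage points higher from compound 2 to compound 3 (within the scatter) is expected to be small, with no clear direction beyond the scatter. Compound 3 is estimated at 30%, within 12% to 55%.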

Compound 3, a percentage reported as activity, at one concentration (the size of the read-out at that concentration, not a potency): 17.8%
For compound 3 the middle estimate is 12.2 percentage points above the measured one; the range from low to high includes it.
By their numbers in this assay, from the lowest: compounds 3 and 2 (each within the scatter of the next); then compound 1.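

In this assay, hydrogen in place of methoxy on this aromatic carbon, meta to a 2-(ethoxycarbonyl)ethenyl group, gives a number 5.6 percentage points lower from compound 2 to compound 3 (within the scatter), so methoxy at this position makes no difference beyond the scatter in the ethyl ester. The large step lies elsewhere: ethyl in place of hydrogen on an oxygen next to a carbonyl group gives a number 44 percentage points lower from compound 1 to compound 3 (beyond the scatter). No supporting data explain either step.

Open, going by these compounds, is whether an amine at the methoxy position would give a step beyond the scatter, and whether a longer chain in place of ethyl would keep the number near that of compound 3.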